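A Propoxy Group Replaces the Nitrile on the Sulfonyl Arene

The source may hold more compounds than are shown below. What is called first, only, known or untested is meant among the compounds shown, and "the series" means these compounds.

For the measured compounds named here, compound 1, `CC1CCN(C2CCN(S(=O)(=O)c3ccc(C#N)cc3)CC2)CC1`, gives 2800 nM in a functional assay on DLD-1 cells (Homo sapiens) for antiproliferative activity, read by CellTiter-Glo, with a stated time of 72 h (a higher number here means a weaker inhibitor, a lower number a stronger inhibitor), the second highest of the three values known so far. Compound 2, `CC1CCN(C2CCN(S(=O)(=O)c3cccc(N)c3)CC2)CC1`, gives 3400 nM, and a 1.2-fold higher number from compound 1 to compound 2 (0.08 log units; within the scatter). Compound 3, `Cc1cccc(S(=O)(=O)N2CCC(N3CCC(C)CC3)CC2)c1`, gives 25 nM, and a 110-fold lower number from compound 1 to compound 3 (2.05 log units; beyond the scatter). Compound 4, `CCCOc1ccc(S(=O)(=O)N2CCC(N3CCC(C)CC3)CC2)cc1`, carries propoxy in place of cyano on an aromatic carbon. Going by the values given here, no measured step exchanges one group for another at that same place, so the closest guide is the large gain from compound 1 to compound 3, where the cyano also left the ring; that gain, however, also involved a move of the group, and the gain of compound 2 over compound 1 was none. A moderate gain is therefore expected, a 7.0-fold lower number from compound 1 to compound 4 (0.85 log units; beyond the scatter), giving for compound 4 an estimated 400 nM in this assay, within 60 nM to 2500 nM.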

Compound 4, half-maximal inhibitory concentration: 452 nM
The estimate for compound 4 lay 1.1-fold (0.05 log units) below the measured number; low and high end bracket the measured number.
By their numbers in this assay, from the lowest: compound 3; then compound 4; then compounds 1 and 2 (each within the scatter of the next).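

At this place, on an aromatic carbon para to a large group, exchanging the nitrile for a propoxy chain gives a 6.2-fold lower number from compound 1 to compound 4 (0.79 log units; beyond the scatter) in this assay. Unlike the earlier large gain, where the new group also sat elsewhere on the ring, this step leaves the place unchanged, so a change at this place alone moves the number beyond the scatter. Nothing measured here explains why propoxy gives the lower number. On these data alone, whether a shorter chain such as methoxy, a longer chain such as butoxy, or an amine would give a lower number at this place remains open.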